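Cyclohexyl amides: methyl to chloro on the pendant phenyl

This account rests on a few compounds, and the source may have more. Where it says the series, first, only, none or still open, it means among the compounds named here.

Measured so far:
compound 1 `CC(C)N1CCc2nc(C#Cc3cccc(Cl)c3)ccc2C1=O` – 100 nM
compound 2 `O=C1c2ccc(C#Cc3ccccc3)nc2CCN1C1CCCCC1` – 12400 nM
compound 3 `Cc1cccc(C#Cc2ccc3c(n2)CCN(C2CCCCC2)C3=O)c1` – 3210 nM

In an assay on HEK293 cells for displacement of a labelled ligand from metabotropic glutamate receptor 5 (Homo sapiens), with a stated time of 2 h (on this read-out lower numbers stand for stronger inhibition and higher numbers for weaker inhibition), compound 3 stands second highest of the three numbers; its nearest neighbour is compound 2 and the furthest is compound 1, which carries the 3-chlorophenyl together with a different amide substituent. Compound 4 `O=C1c2ccc(C#Cc3cccc(Cl)c3)nc2CCN1C1CCCCC1` is the next member; it differs from compound 3 by chloro in place of methyl on an aromatic carbon. Among the measured compounds shown here, the only measured step that bears on this position is a 3.9-fold lower number from compound 2 to compound 3 (0.59 log units; beyond the scatter), which shows that a substituent there lowers the number. For the measured compounds named here, no measured pair compares chloro with methyl directly, so the change is expected to give at most a small step in this assay, likely toward a lower number. Compound 4 is therefore expected at 1600 nM (range 400 nM to 5000 nM), an estimated step of a 2.0-fold lower number from compound 3 to compound 4 (0.30 log units; within the scatter).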

Compound 4, inhibition constant: 12000 nM
Beside the measured number, compound 4's estimate is 7.5-fold (0.88 log units) below it, and the stated range ends below it.
By their numbers in this assay, from the lowest: compound 1; then compound 3; then compounds 4 and 2 (each within the scatter of the next).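

In the cyclohexyl amides, this assay does not treat 3-chlorophenyl like 3-methylphenyl (a 3.7-fold higher number from compound 3 to compound 4 (0.57 log units; beyond the scatter)), so the effect seen with methyl does not extend to chloro. Chloro in place of hydrogen leaves the number within the scatter (a 1.0-fold lower number from compound 2 to compound 4 (0.01 log units; within the scatter)). With 3-chlorophenyl held constant, cyclohexyl in place of isopropyl gives a far larger step (a 120-fold higher number from compound 1 to compound 4 (2.08 log units; beyond the scatter)), so the low number of compound 1 depends on its amide substituent. Nothing available explains the difference between chloro and methyl. Open, as far as these compounds go, is whether methoxy or nitrile at this place would follow methyl or chloro, and whether 3-methylphenyl would also differ from 3-chlorophenyl on the isopropyl amide.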